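This account rests on a few compounds, and the source may have more. Where it says the series, first, only, none or still open, it means among the compounds named here.

Of the compounds shown here, three have been measured so far in a functional assay on NCI/ADR-RES cells (Homo sapiens) for inhibition; a lower number here means a stronger inhibitor of growth, a higher number a weaker inhibitor of growth. Compound 2 `C=C1CCC[C@H]2[C@](C)(CC[C@]3(C)CC[C@@H]([C@@H](C)C(=O)O)OO3)[C@@H](C)CC[C@]12C` gives 770 nM in this assay. Compound 1 `C=C1CCCC(C)(C)C1CC[C@]1(C)CC[C@@H]([C@@H](C)C(=O)O)OO1` gives only a limit in this assay, namely > 10000 nM. Compound 3 `CC1=C(CC/C(C)=C/CC[C@@]2(C)CC[C@@H]([C@H](C)C(=O)O)OO2)C(C)(C)CCC1` likewise gives only a limit in this assay, > 100000 nM, and so sits at the limit of > 100000 nM in this assay, at which 1 of the 3 values shown sits; no number is known for it. The next compound, compound 4 `CC1=C(CC/C(C)=C/CC[C@@]2(C)CC[C@H]([C@H](C)C(=O)O)OO2)C(C)(C)CCC1`, differs from it as follows: the two compounds have the same atoms and bonds and differ only in configuration as drawn: 1 of 4 stereo elements differ; a stereocentre at a saturated ring carbon is drawn S in compound 3 and R in compound 4. For the measured compounds named here, no pair of measured compounds differs in a single place, so no measured step shows how large such a change tends to be. With compound 3 anchored only by a limit, a modest shift toward stronger inhibition is expected, as an at least 2.0-fold lower number from compound 3 to compound 4 (0.30 log units; that floor lies within the scatter). Compound 4 is therefore estimated at 50000 nM in this assay, with a range of 5000 nM to 300000 nM.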

Compound 4, concentration for 50% growth inhibition: > 5000 nM
Compound 4: a limit, no number (the forecaster's own chance of this, stated with the estimate: 60%); the middle value is on the limit's open side.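

In this assay compound 3 at > 100000 nM is only a limit. For the compounds shown here, compound 4 at > 5000 nM is also only a limit, so no step between compound 3 and compound 4 can be read. From the compounds shown here alone, whether the S or the R configuration at the saturated ring carbon gives the stronger inhibitor of growth stays open.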